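A pyridin-2-yl to phenethyl swap awaiting measurement

The source may report more compounds than this note shows. Statements on the series, on what has been measured and on what is new or still open speak of the compounds shown alone.

Measured so far in a functional assay on CHO cells for activation of 5-hydroxytryptamine receptor 1D (Homo sapiens), read by GTPgammaS binding; a lower number here means that less compound is needed, a higher number that more compound is needed for the effect:
Compound 1, `c1ccc(CN2CCN(CCCc3c[nH]c4ccc(-n5cnnc5)cc34)CC2)nc1`, gives 0.3 nM.
Compound 2, `c1cc(CN2CCN(CCCc3c[nH]c4ccc(-n5cnnc5)cc34)CC2)ccn1`, gives 1 nM.

Going by the values given here, compound 1 holds the lowest of the two numbers, and its nearest neighbour is compound 2; the single measured step between them is a 3.3-fold higher number from compound 1 to compound 2 (0.52 log units; beyond the scatter). Compound 3, `c1ccc(CCCN2CCN(CCCc3c[nH]c4ccc(-n5cnnc5)cc34)CC2)cc1`, has not yet been measured. It differs from compound 1 by phenethyl in place of pyridin-2-yl on a saturated chain carbon bound to an amine nitrogen in a ring. Among the compounds with values here, no measured pair shows this exact change. The step from compound 1 to compound 2 is the only one that touches the same place, and there an exchange of one six-membered aromatic ring for another gave a modest rise. Within the data shown here, the change to compound 3 is of a different kind, exchanging a ring with one hetero atom and one hydrogen-bond acceptor for a longer, carbon-only phenethyl group, so the measured step serves only as a rough guide; a modest rise in the number is expected, with no measured pair securing the direction. Compound 3 is therefore estimated at 1 nM, within 0.3 nM to 4 nM. This estimate corresponds to an expected step of a 3.3-fold higher number from compound 1 to compound 3 (0.52 log units; beyond the scatter).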

Compound 3, half-maximal effective concentration: 4 nM
Compound 3: the middle estimate sits 4.0-fold (0.60 log units) below what was measured; measured number inside the range.
By their numbers in this assay, from the lowest: compound 1; then compound 2; then compound 3.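

In this assay, the place on a saturated chain carbon bound to an amine nitrogen in a ring now shows a wider spread of numbers than the two pyridine isomers alone revealed. Replacing pyridin-2-yl with phenethyl gives a 13-fold higher number from compound 1 to compound 3 (1.12 log units; beyond the scatter) and is rated large, whereas the step between the isomers was modest. The same replacement starting from pyridin-4-yl gives a 4.0-fold higher number from compound 2 to compound 3 (0.60 log units; beyond the scatter) and is rated modest, so the size of the change depends on which pyridine it replaces, and pyridin-2-yl gives the largest rise among these compounds.

The compounds shown leave open how much of the rise belongs to the loss of the ring nitrogen and how much to the change from (pyridin-2-yl)methyl to 3-phenylpropyl, as both differences arrive together in compound 3; a benzyl group or a 3-(pyridin-2-yl)propyl group at this place would separate the two. The data shown also offer no measurement that accounts for the size of either step.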